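Bromo in place of chloro on an aromatic carbon

A few compounds are considered here, and "the series" means these few. Any claim that something is new, unique, unknown or untested is made for them only; others in the source may bear on it.

compound 1 `CN(C)C(=O)c1cc2cnc(Nc3ccc(NC(=O)C4(C(=O)Nc5ccc(F)cc5)CC4)cc3)nc2n1C1CCCC1`: 79.7%
compound 2 `CN(C)C(=O)c1cc2cnc(Nc3ccc(NC(=O)C4(C(=O)Nc5cccc(Cl)c5)CC4)cc3)nc2n1C1CCCC1`: 88.1%
compound 3 `CN(C)C(=O)c1cc2cnc(Nc3ccc(NC(=O)C4(C(=O)Nc5cccc(Br)c5)CC4)cc3)nc2n1C1CCCC1`: not yet measured

For the measured compounds named here, in a functional assay on OVCAR-5 cells (Homo sapiens) for inhibition, read by CCK-8 assay, with a stated time of 72 h, tested at 10 uM (a higher number here means more inhibition of growth at the concentration tested, a lower number less inhibition of growth), compound 2 gives 88.1%, within the scatter of compound 1, the only other measured compound. Compound 3 carries one change from compound 2: bromo in place of chloro on an aromatic carbon. Going by the values given here, the sole measured step that bears on it is a number 8.4 percentage points higher from compound 1 to compound 2 (within the scatter), where 3-chlorophenyl replaces 4-fluorophenyl. No step beyond the scatter is therefore expected in this assay. The expected step is a number 1.1 percentage points lower from compound 2 to compound 3 (within the scatter). Compound 3 is estimated at 87%, with an expected range of 76% to 97%.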

Compound 3, percent growth inhibition at one concentration: 89.6%
Estimate against measurement, compound 3: 2.6 percentage points below; low and high end bracket the measured number.
By their numbers in this assay, from the lowest: compounds 1, 2 and 3 (each within the scatter of the next).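

In this assay bromo in place of chloro gives a number 1.5 percentage points higher from compound 2 to compound 3 (within the scatter), so at this aromatic carbon the two halogens cannot be told apart. Set against 4-fluorophenyl, 3-bromophenyl gives a number 9.9 percentage points higher from compound 1 to compound 3 (within the scatter), which places all three substituted phenyl groups shown within the scatter of one another. Nothing available explains this result.

The compounds shown leave open whether an amine, a methoxy group or a plain phenyl would hold this level of inhibition. They also leave open whether any change at this place can produce a step beyond the scatter.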